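The source may hold more compounds than are shown below. What is called first, only, known or untested is meant among the compounds shown, and "the series" means these compounds.

Compound 1 `O=C(Nc1ccc(C(F)(F)F)cc1)NC1CCN(C(=O)C2CCOC2)CC1` was tested in a physicochemical assay for lipophilicity, read by HPLC, with a stated time of 90 min, tested at 100 uM (on this read-out higher numbers stand for higher lipophilicity and lower numbers for lower lipophilicity), where compound 1 gives 3.16. Compound 3 `O=C(Nc1ccc(OC(F)(F)F)cc1)NC1CCN(C(=O)C2CCOC2)CC1` gives 3.22 in this assay, and compound 2 `CCC(=O)N1CCC(NC(=O)Nc2ccc(C(F)(F)F)c(F)c2)CC1` gives 3.76. Compound 1 thus has the lowest of the three numbers shown, although compound 3 lies within the scatter of it, while compound 2 stands beyond the scatter of compound 1. Among the measured compounds shown here, the one step between neighbours that differ in a single place is a number 0.06 log units higher from compound 1 to compound 3 (within the scatter), a swap of trifluoromethoxy in place of trifluoromethyl on an aromatic carbon.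

Compound 4 `O=C(Nc1ccc(C(F)(F)F)cc1)NC1CCN(C(=O)[C@@H]2CCOC2)CC1` is the untested compound. the two compounds have the same atoms and bonds; at least one stereo element is drawn with a configuration in one of them and without one in the other: 1 of 1 stereo elements differ; a stereocentre at a saturated ring carbon is drawn without a configuration in compound 1 and R in compound 4 Compound 1 and compound 4 therefore have the same atoms and bonds; a stereocentre at a saturated ring carbon is drawn without a configuration in compound 1 and R in compound 4. For the measured compounds named here, no measured step here involves such a change in drawn configuration, and the step from compound 1 to compound 3 concerns a substituent, not a stereocentre, so none of the measured steps bears directly on this one. With the same atoms and bonds on both sides, the expected step in this assay is no change at the digits printed from compound 1 to compound 4 (within the scatter), meaning no change beyond the scatter is expected. Compound 4 is accordingly estimated at 3.16, with a range from 2.96 to 3.36.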

Compound 4, partition coefficient: 3.27
The estimate for compound 4 lay 0.11 log units below the measured number; low and high end bracket the measured number.
By their numbers in this assay, from the lowest: compounds 1, 3 and 4 (each within the scatter of the next); then compound 2.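

Drawing the stereocentre at a saturated ring carbon as R gives, in this assay, a number 0.11 log units higher from compound 1 to compound 4 (within the scatter). Among the compounds shown here, the earlier step touched only a substituent on an aromatic carbon, so this is the first reading at this stereocentre, and the read-out does not separate compound 4 from compound 1. The comparison says little about R against S, because the two drawings do not define the same thing at this stereocentre: the fact that one of compounds 1 and 4 is drawn with a defined configuration and the other without, at the place where they differ

The compounds shown leave open how a compound drawn S at this stereocentre would read in this assay. They also leave open whether replacing the trifluoromethyl on an aromatic carbon with a carboxylic acid or an amine would give a step beyond the scatter.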